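Extending an aryl ether: the second branch of a pair

A few compounds are considered here, and "the series" means these few. Any claim that something is new, unique, unknown or untested is made for them only; others in the source may bear on it.

Measured so far:
compound 1 `O=C(COc1ccc(OC(F)(F)F)cc1)N[C@@H]1COc2nc([N+](=O)[O-])cn2C1` — 43 ug/mL
compound 2 `O=C(NCc1ccc(OC(F)(F)F)cc1)O[C@@H]1COc2nc([N+](=O)[O-])cn2C1` — 10 ug/mL
compound 3 `O=C(COc1ccc(-c2ccc(OC(F)(F)F)cc2)cc1)N[C@@H]1COc2nc([N+](=O)[O-])cn2C1` — 0.96 ug/mL

All three share a nitroimidazole-fused core and were tested in a physicochemical assay for solubility, read by HPLC, measured as kinetic solubility, at pH 7; a higher number here means a more soluble compound, a lower number a less soluble compound. Compound 1 and compound 2 are built from the same atoms joined differently; the difference between their two cores is not broken down here. Between them, compound 2 sits lower, with compound 1 giving the higher of the two numbers.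

For the measured compounds named here, the one change that is both made and measured is 4-(trifluoromethoxy)phenyl in place of trifluoromethoxy on an aromatic carbon, and it produced a 45-fold lower number from compound 1 to compound 3 (1.65 log units; beyond the scatter). Compound 4 `O=C(NCc1ccc(-c2ccc(OC(F)(F)F)cc2)cc1)O[C@@H]1COc2nc([N+](=O)[O-])cn2C1`, which is not yet measured, carries the same change made on compound 2, namely (4-(trifluoromethoxy)phenyl in place of trifluoromethoxy on an aromatic carbon); the place of the change is the same in both pairs.

Going by the values given here, with only one measured example of this change, the expectation for compound 4 rests on that single step together with the value of compound 2. From compound 2 to compound 4 a step of about a 33-fold lower number from compound 2 to compound 4 (1.52 log units; beyond the scatter) is expected in this assay, because the same change gave a 45-fold lower number from compound 1 to compound 3 (1.65 log units; beyond the scatter). Compound 4 is therefore estimated at 0.3 ug/mL, most likely between 0.08 ug/mL and 1.2 ug/mL.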

Compound 4, solubility: 0.34 ug/mL
Compound 4: middle estimate off by 1.1-fold (0.05 log units), on the low side; the range from low to high includes it.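

In this assay, putting 4-(trifluoromethoxy)phenyl in place of trifluoromethoxy on an aromatic carbon gave a 29-fold lower number from compound 2 to compound 4 (1.47 log units; beyond the scatter), a large step in the same direction as a 45-fold lower number from compound 1 to compound 3 (1.65 log units; beyond the scatter), and both steps lie beyond the usual scatter. So the change carried over from the core of compound 1 to the core of compound 2, and neither pair goes against this, but two pairs show only what happened on these two cores and do not amount to a rule for any other core in the series. Nothing shown here explains the size or direction of either step.

Going by these compounds, it remains open whether the same step would appear if the added phenyl ring carried an amine or a carboxylic acid in place of trifluoromethoxy. On these data alone, it also remains open whether a third core, joined to the same two groups, would follow the same course.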